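From methoxy to trifluoromethyl on compound 1

The compounds below may be only part of what the source reports. "The series", "measured", "known", "first", "only" and "open" are said of these compounds alone.

Compound 1 (`CCN(CC)c1ccc(-c2cccc(OC)c2)nn1`) is the starting point in an ADME assay on cells (Fibroblast, Homo sapiens) for antiproliferative activity, with a stated time of 48 h; on this read-out higher numbers stand for weaker inhibition and lower numbers for stronger inhibition. There, compound 1 gives > 25000 nM, which is a limit of the assay and not a number. Compound 2 (`CC(=O)c1ccc(-c2ccc(N3CCCC3)nn2)cc1`) gives > 25000 nM, which is also a limit. The record so far is therefore (the limit of > 25000 nM in this assay, at which 2 of the 2 values shown sit).

Compound 3 (`CCN(CC)c1ccc(-c2cccc(C(F)(F)F)c2)nn1`) has trifluoromethyl in place of methoxy on an aromatic carbon, meta to a large group: trifluoromethyl in place of methoxy on an aromatic carbon. Going by the values given here, no measured step gives a size for this change, and the two values offer no number to start from. With compound 1 standing at the limit of > 25000 nM, no step beyond the scatter is expected in this assay, in either direction. The estimated step, a number no higher from compound 1 to compound 3 (the limit leaves the size open), is accordingly expected to be small. Compound 3 is expected at 25000 nM, with an estimated range of 10000 nM to 50000 nM.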

Compound 3, half-maximal inhibitory concentration: > 25000 nM
Compound 3 gave a limit, no number; the forecaster's own chance of this, stated with the estimate: 70%; the middle value lies on the limit itself.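

The step between compound 1 and compound 3 cannot be read, because both values are limits and not numbers: the limit of > 25000 nM in this assay, at which 3 of the 3 values shown sit.

The compounds shown leave open how trifluoromethyl and methoxy compare, and whether any change to the shared core gives a readable number in this assay at all.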